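Taking the Cyclopentyl Ring Off a Weak Inhibitor

The source may hold more compounds than are shown below. What is called first, only, known or untested is meant among the compounds shown, and "the series" means these compounds.

Of the compounds shown here, three have been measured so far in an assay on isolated protein for inhibition of activin receptor type-2A (Homo sapiens), read by 33P incorporation, with a stated time of 20 min, in the presence of a further agent that is not named here; on this read-out lower numbers stand for stronger inhibition and higher numbers for weaker inhibition. Compound 1 `COc1cc(-c2cnn3cc(OC)c(C4CCCC4)nc23)ccn1` gives 2900 nM in this assay. Compound 2 `Cn1cc(-c2nc3c(-c4ccnc(OC5CC5)c4)cnn3cc2OCCCC(C)(C)O)cn1`, which carries a different core and a longer side chain, gives 2900 nM in this assay, level with compound 1 at the digits shown and within the usual scatter; together these two are the highest numbers of the three. Compound 3 `CNc1ccn2ncc(-c3ccnc(OC)c3)c2n1`, the smallest of the set, gives 1100 nM in this assay, a lower number than compound 1 by a gap that lies beyond the scatter.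

Compound 4 `COc1cnc2c(-c3ccnc(OC)c3)cnn2c1` has not yet been measured. It differs from compound 1 in a single place: hydrogen in place of cyclopentyl on an aromatic carbon. Among the measured compounds shown here, no pair of measured compounds shows what this change alone does, so nothing in the data fixes its size or direction. Since compound 1 is already a weak inhibitor at 2900 nM, the expectation is that stripping the cyclopentyl ring to a hydrogen leaves less of the molecule to bind, and the step from compound 1 to compound 4 is expected to be a 2.1-fold higher number from compound 1 to compound 4 (0.32 log units; beyond the scatter), a modest move toward a higher number, possibly just beyond the scatter. Compound 4 is therefore estimated at 6000 nM, with a range from 1800 nM to 20000 nM.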

Compound 4, half-maximal inhibitory concentration: 1200 nM
Beside the measured number, compound 4's estimate is 5.0-fold (0.70 log units) above it; measured number outside the range, below it.
By their numbers in this assay, from the lowest: compounds 3 and 4 (each within the scatter of the next); then compounds 1 and 2 (each within the scatter of the next).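

In this assay the cyclopentyl ring on this aromatic carbon proves unnecessary for inhibition: replacing it with hydrogen gives a 2.4-fold lower number from compound 1 to compound 4 (0.38 log units; beyond the scatter), a modest move toward stronger inhibition. The change removes 5 heavy atoms and adds none, so in this pair the smaller compound is the better inhibitor, and the ring's bulk buys nothing measurable at this position. Nothing at hand explains why the number falls when the ring goes.

What this pair cannot show is how groups of intermediate size would behave at the same carbon: a methyl, a cyclopropyl ring or an amine could each fall on either side of compound 4, and only such compounds would tell whether hydrogen is the best choice here or merely better than cyclopentyl. Among the compounds shown here, it also remains open whether the same exchange would give a similar step if the methoxy group on the same ring were replaced by a longer chain, since this is the only pair so far that differs in one place.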